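Phenyl in place of a methoxyethyl chain on the amide

A few compounds are considered here, and "the series" means these few. Any claim that something is new, unique, unknown or untested is made for them only; others in the source may bear on it.

Of the compounds shown here, three sharing one core have been tested in an ADME assay on C8166 cells (Homo sapiens) for cytotoxicity, read by MTT assay, with a stated time of 3 days; on this read-out lower numbers stand for higher toxicity in this test and higher numbers for lower toxicity in this test. Compound 1 `CC(C)(NC(=O)OCc1ccccc1)c1nc(O)c(O)c(C(=O)NN)n1` gives only a limit of the assay, > 500000 nM. Compound 2 `CC(C)(NC(=O)OCc1ccccc1)c1nc(O)c(O)c(C(=O)NCC2CC2)n1` gives 204000 nM. Within the data shown here, compound 3 `COCCCNC(=O)c1nc(C(C)(C)NC(=O)OCc2ccccc2)nc(O)c1O` gives 259000 nM, a number that sits within the scatter of the one from compound 2. Compound 4 `CC(C)(NC(=O)OCc1ccccc1)c1nc(O)c(O)c(C(=O)NCc2ccccc2)n1` differs from compound 3 by phenyl in place of 2-methoxyethyl on a saturated chain carbon bound to an amide-type nitrogen. The step bearing most on this change is a 1.3-fold higher number from compound 2 to compound 3 (0.10 log units; within the scatter), where a different group on the same carbon shifted little, and an at least 1.9-fold lower number from compound 1 to compound 3 (0.28 log units; that floor lies within the scatter) also stayed at the edge of the scatter. A step of similar small size is therefore expected in this assay for compound 4, a 1.1-fold lower number from compound 3 to compound 4 (0.05 log units; within the scatter). Compound 4 is estimated at 230000 nM, between 120000 nM and 450000 nM.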

Compound 4, half-maximal cytotoxic concentration: 41400 nM
Compound 4: middle estimate off by 5.6-fold (0.74 log units), on the high side, outside the stated range (below it).
By their numbers in this assay, from the lowest: compound 4; then compounds 2 and 3 (each within the scatter of the next). At a limit, above all of these: compound 1.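

In this assay, the group on the amide-type nitrogen can matter after all: the two saturated chains stayed within the scatter of each other, but the benzyl group brings a 6.3-fold lower number from compound 3 to compound 4 (0.80 log units; beyond the scatter) and a 4.9-fold lower number from compound 2 to compound 4 (0.69 log units; beyond the scatter), so toxicity in this test is higher. Compound 1 gives only a limit, so an at least 12-fold lower number from compound 1 to compound 4 (1.08 log units; beyond the scatter) is a floor: the limit of > 500000 nM in this assay, at which 1 of the 4 values shown sits.

Whether the aromatic ring itself accounts for this stays open. A cyclohexylmethyl group, a pyridylmethyl group or a longer 2-phenylethyl chain on the same nitrogen would help to tell.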